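This account rests on a few compounds, and the source may have more. Where it says the series, first, only, none or still open, it means among the compounds named here.

Compound 3 `O=C(Nc1ccc(Oc2ccnc3[nH]ccc23)cc1)c1cc(-c2ccc(F)cc2)ncn1` gives 15900 nM in a functional assay on MCF7 cells (Homo sapiens) for cytotoxicity, read by MTT assay, with a stated time of 72 h (a higher number here means a weaker inhibitor, a lower number a stronger inhibitor), the highest of the two numbers reported there; its nearest neighbour is compound 2 `COc1ccc(-c2cc(C(=O)Nc3ccc(Oc4ccnc5[nH]ccc45)cc3)ncn2)cc1`, which gives 4450 nM, and the step of a 3.6-fold higher number from compound 2 to compound 3 (0.55 log units; beyond the scatter) lies beyond the scatter. Compound 1 `O=C(Nc1ccc(Oc2ccnc3[nH]ccc23)cc1)c1nccc(-c2ccc(Cl)cc2)n1`, built on a different arrangement of the shared core, is reported in this assay as "not active" (no number reported), with no number attached. Compound 4 `O=C(Nc1ccc(Oc2ccnc3[nH]ccc23)cc1)c1cc(-c2ccc(Cl)cc2)ncn1` differs from compound 3 by chloro in place of fluoro on an aromatic carbon. Among the measured compounds shown here, no measured pair shows this exchange directly: the only step on record, from methoxy to fluoro, concerns a different group, and compound 1 carries chloro on another core, so it does not describe this step. With nothing to indicate a shift beyond the scatter, the step of a 1.3-fold lower number from compound 3 to compound 4 (0.12 log units; within the scatter) is expected to be small in this assay. Compound 4 is therefore estimated at 12000 nM, within a range of 4000 nM to 40000 nM, in this assay.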

Compound 4, half-maximal inhibitory concentration: 7770 nM
Estimate against measurement, compound 4: 1.5-fold (0.19 log units) above, within the range that was stated.
By their numbers in this assay, from the lowest: compounds 2 and 4 (each within the scatter of the next); then compound 3.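

In this assay the 4-fluorophenyl to 4-chlorophenyl exchange can now be read directly: a 2.0-fold lower number from compound 3 to compound 4 (0.31 log units; beyond the scatter) lies just beyond the scatter, so this change at the place on the aromatic ring does register. The step of a 1.7-fold higher number from compound 2 to compound 4 (0.24 log units; within the scatter) stays within the scatter, so chloro and methoxy cannot be told apart here, and among these three groups fluoro alone stands apart, with the highest number. Nothing measured here explains this order of the groups.

The compounds shown leave open whether an amine, a methyl group or no group at all in that place would fall with chloro and methoxy or with fluoro. From the compounds shown here alone, compound 1 carries no number, so what its different core arrangement does to a chloro compound also stays open.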